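The source may report more compounds than this note shows. Statements on the series, on what has been measured and on what is new or still open speak of the compounds shown alone.

Working notes on a series built on one shared core. Compound 1 `Nc1nc(NC2CCCCC2)c2ncn(/C=C3/CC3(CO)CO)c2n1`, compound 2 `CCCNc1nc(N)nc2c1ncn2/C=C1/CC1(CO)CO` and compound 3 `CCCCNc1nc(N)nc2c1ncn2/C=C1/CC1(CO)CO` have been through an ADME assay on MOLT-3 cells (Homo sapiens) for cytotoxicity, with a stated time of 7 days; on this read-out lower numbers stand for higher toxicity in this test and higher numbers for lower toxicity in this test; compound 4 `Nc1nc(SC2CCCC2)c2ncn(/C=C3/CC3(CO)CO)c2n1` has not. For compound 1 the entry in this assay reads "not determined" (no result reported). For compound 2 the entry in this assay likewise reads "not determined" (no result reported). Compound 3 gives only a limit in this assay, namely > 20000 nM. For the measured compounds named here, that limit is the single value the set offers, and it is the limit of > 20000 nM in this assay, at which 1 of the 3 values shown sits. Going by the values given here, no step between measured compounds can be computed, so compound 3 stands as the sole reference, and it stands at a limit rather than at a number.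

The change from compound 3 to compound 4 is cyclopentylsulfanyl in place of butylamino on an aromatic carbon. Among the compounds with values here, with no measured step to lean on, the expectation in this assay is no step beyond the scatter in either direction, and most probably a second limit. The expected step from compound 3 to compound 4 is estimated as a step that the limit leaves unreadable from compound 3 to compound 4. Compound 4 is expected to show 25000 nM, with a range from 8000 nM to 80000 nM, and the greater chance is that only a limit is reported again.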

Compound 4, half-maximal cytotoxic concentration: > 20000 nM
Compound 4 gave a limit, no number (the forecaster's own chance of this, stated with the estimate: 70%); the middle value is on the limit's open side.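

Compound 3 and compound 4 both end in a limit rather than a number, so no step between them can be read in this assay: the limit of > 20000 nM in this assay, at which 2 of the 4 values shown sit.

The compounds shown leave open whether cyclopentylsulfanyl in place of butylamino on an aromatic carbon shifts the half-maximal cytotoxic concentration at all, and where on the scale either compound truly lies.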